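Removing a Fluoro Group: Expected Effect on Cell Growth Inhibition

The source may report more compounds than this note shows. Statements on the series, on what has been measured and on what is new or still open speak of the compounds shown alone.

Compound 1 `CCCSc1nc(N/N=C/c2ccccc2Cl)c2nnn(Cc3ccccc3)c2n1`: 10900 nM
Compound 2 `CCCSc1nc(N/N=C(\C)c2ccccc2O)c2nnn(Cc3ccc(F)cc3)c2n1`: 11000 nM

Both compounds were tested in a functional assay on MGC-803 cells (Homo sapiens) for antiproliferative activity, read by MTT assay, with a stated time of 72 h; a lower number here means a stronger inhibitor, a higher number a weaker inhibitor. Compound 2 gives 11000 nM, the higher of the two numbers, but its gap to compound 1 lies within the usual scatter, so the two cannot be ranked. Compound 3 `CCCSc1nc(N/N=C(\C)c2ccccc2O)c2nnn(Cc3ccccc3)c2n1` differs from compound 2 by hydrogen in place of fluoro on an aromatic carbon, so that a 4-fluorobenzyl becomes a benzyl. Among the compounds with values here, no measured pair isolates this change. The expected step is no change at the digits printed from compound 2 to compound 3 (within the scatter), nothing beyond the scatter. Compound 3 is estimated at 11000 nM, in the range 5000 nM to 25000 nM.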

Compound 3, half-maximal inhibitory concentration: 2310 nM
For compound 3 the middle estimate is 4.8-fold (0.68 log units) above the measured one; measured number below the stated range.
By their numbers in this assay, from the lowest: compound 3; then compounds 1 and 2 (each within the scatter of the next).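

In this assay, putting hydrogen in place of the fluoro, so that a 4-fluorobenzyl becomes a benzyl, gives a 4.8-fold lower number from compound 2 to compound 3 (0.68 log units; beyond the scatter): one atom at this position is enough to move the number beyond the scatter. With the benzyl shared, exchanging the chlorine-bearing group for the oxygen-bearing one gives a 4.7-fold lower number from compound 1 to compound 3 (0.67 log units; beyond the scatter). Nothing available explains why removing the fluoro lowers the number. From the compounds shown here alone, how a chloro, a methoxy or an amine would fare at this position remains open, as does whether the same step would appear with the chlorine-bearing group in place.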